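Shortening the Amide Linker in Two Cores

The source may report more compounds than this note shows. Statements on the series, on what has been measured and on what is new or still open speak of the compounds shown alone.

Compound 1 `CC(C)n1c(=O)n(C(=O)NCC2CCNCC2)c2ccccc21` reaches 92% in a functional assay on HEK293 cells for activation of 5-hydroxytryptamine receptor 4 (Homo sapiens), read by cAMP accumulation; a higher number here means a larger maximal response, a lower number a smaller maximal response. Compound 2 `CC(C)n1c(=O)n(C(=O)NC2CCNCC2)c2ccccc21` is recorded in this assay at > 100%, which is a limit of the assay and not a number (the limit of > 100% in this assay, at which 1 of the 3 values shown sits). The change between them is piperidin-4-yl in place of (piperidin-4-yl)methyl on an amide-type nitrogen, and it gave a step of a number at least 8 percentage points higher from compound 1 to compound 2 (that floor lies within the scatter). Compound 3 `COc1ccc2[nH]cc(C(=O)NCC3CCNCC3)c2c1` gives 42% in this assay; how its core differs from that of compound 1 is not broken down here. Compound 4 `COc1ccc2[nH]cc(C(=O)NC3CCNCC3)c2c1` carries the same change relative to compound 3, namely (piperidin-4-yl in place of (piperidin-4-yl)methyl on an amide-type nitrogen), at the same place. The expected step is a number 10 percentage points higher from compound 3 to compound 4 (within the scatter), resting on the measured step of a number at least 8 percentage points higher from compound 1 to compound 2 (that floor lies within the scatter), which pointed upward only within the scatter. For compound 4 the estimated intrinsic activity is therefore 52%, between 32% and 78%.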

Compound 4, intrinsic activity: the largest response reached, in percent of the reference agonist's: 0%
The estimate for compound 4 lay 52 percentage points above the measured number; measured number below the stated range.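

In this assay the change from (piperidin-4-yl)methyl to piperidin-4-yl on the amide-type nitrogen gave a number 42 percentage points lower from compound 3 to compound 4 (beyond the scatter) and so did not carry over from the core of compound 1 to the core of compound 3: the same change on two cores in this assay, a number at least 8 percentage points higher (that floor lies within the scatter) from compound 1 to compound 2 and a number 42 percentage points lower (beyond the scatter) from compound 3 to compound 4, at least 50 percentage points apart, beyond the scatter of two such steps.

Going by these compounds, compound 2 stands at > 100% which is a limit of the assay and not a number, so the full size of the step on its core stays unknown. With one pair on each core, these four compounds show that the outcome of this change depends on the core, but they do not show why, or how it would go on any other core.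

The compounds shown leave open how a longer chain on the amide-type nitrogen, such as (piperidin-4-yl)ethyl, would behave on either core. They also leave open whether an N-methylpiperidine would follow the same split.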